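The source may hold more compounds than are shown below. What is called first, only, known or untested is meant among the compounds shown, and "the series" means these compounds.

Measured compounds:
Compound 1 `COc1cccc(Nc2nccc(-c3ccc(Br)cc3)n2)c1` gives 977 nM in an assay on isolated protein for inhibition of phosphatidylinositol 4,5-bisphosphate 3-kinase catalytic subunit beta isoform (Homo sapiens); on this read-out lower numbers stand for stronger inhibition and higher numbers for weaker inhibition.
Compound 2 `COc1ccc(-c2ccnc(Nc3ccc(Cl)cc3)n2)cc1` gives 603 nM in this assay.
Compound 3 `Clc1ccc(Nc2nccc(-c3ccc(Br)cc3)n2)cc1` gives 946 nM in this assay.

Compound 3 stands second highest of the three numbers, and all three lie within the scatter of one another. Compound 4 `Cc1cccc(Nc2nccc(-c3ccc(Br)cc3)n2)c1` differs from compound 3 by 3-methylphenyl in place of 4-chlorophenyl on a nitrogen on an aromatic ring. Among the compounds with values here, the only counted step, a 1.6-fold higher number from compound 2 to compound 3 (0.20 log units; within the scatter), concerns a different place and is within the scatter. Compound 1 and compound 3 already carry different groups on that nitrogen, and their values are within the scatter of each other, so the account gives no ground to expect a step beyond the scatter. The step to compound 4 is therefore expected to be a 1.0-fold higher number from compound 3 to compound 4 (0.00 log units; within the scatter). Compound 4 is estimated at 950 nM, between 450 nM and 2000 nM.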

Compound 4, half-maximal inhibitory concentration: > 1000 nM
Compound 4: no number, only a limit; the forecaster's own chance of this, stated with the estimate: 5%; at least 1.0-fold (0.02 log units) between middle value and limit.
By their numbers in this assay, from the lowest: compounds 2, 3 and 1 (each within the scatter of the next). At a limit, above all of these: compound 4.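

Compound 4 carries no number, only a limit: the limit of > 1000 nM in this assay, at which 1 of the 4 values shown sits. The data give an at least 1.0-fold higher number from compound 3 to compound 4 (0.02 log units; that floor lies within the scatter) and an at least 1.0-fold higher number from compound 1 to compound 4 (0.01 log units; that floor lies within the scatter), so neither 3-methylphenyl in place of 4-chlorophenyl on the nitrogen nor methyl in place of methoxy on the aromatic carbon is shown to move the reading beyond the scatter. Of the groups shown on this nitrogen, 3-methylphenyl alone gives a limit rather than a number. As far as these compounds go, how far the true value of compound 4 lies from its limit stays open. So does whether an amine or a carboxylic acid in place of the methyl would give a lower number.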